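This account rests on a few compounds, and the source may have more. Where it says the series, first, only, none or still open, it means among the compounds named here.

Measured so far in a functional assay (mast cells) for inhibition, with Rattus norvegicus as the target; a lower number here means that less compound is needed, a higher number that more compound is needed for the effect:
Compound 1 `CC1CC/C(=N\Nc2ccc(O)cc2)c2ncc(C(=O)O)c(=O)n21` gives 1300 nM
Compound 2 `CC1CC/C(=N\Nc2ccc(C(F)(F)F)cc2)c2ncc(C(=O)O)c(=O)n21` gives 280 nM

Among the compounds with values here, compound 2 stands lowest of the two, with 280 nM as its number, and compound 1 is its only neighbour. Compound 3 `CC(=O)c1ccc(N/N=C2\CCC(C)n3c2ncc(C(=O)O)c3=O)cc1` is still unmeasured and differs from compound 2 in one place: acetyl in place of trifluoromethyl on an aromatic carbon describes acetyl in place of trifluoromethyl on an aromatic carbon.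

Within the data shown here, only one measured step bears on this change (a 4.6-fold lower number from compound 1 to compound 2 (0.67 log units; beyond the scatter)), since it concerns the same aromatic carbon, where trifluoromethyl stands in place of hydroxy. That step is modest but beyond the scatter. Among the measured compounds shown here, it offers only indirect guidance, as no measured compound carries acetyl. A shift smaller than that step is therefore expected in this assay as a slight move towards a higher number, possibly no larger than the scatter. The expected step is a 1.4-fold higher number from compound 2 to compound 3 (0.15 log units; within the scatter) on this estimate. For compound 3 the expected value is 400 nM (estimated range 150 nM to 1100 nM).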

Compound 3, half-maximal effective concentration: 8100 nM
For compound 3 the middle estimate is 20-fold (1.31 log units) below the measured one; measured number above the stated range.
By their numbers in this assay, from the lowest: compound 2; then compound 1; then compound 3.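

In this assay, replacing trifluoromethyl with acetyl on this aromatic carbon, para to a large group, gives a 29-fold higher number from compound 2 to compound 3 (1.46 log units; beyond the scatter), so this position responds far more sharply to a change of group than the single earlier step had shown. Acetyl also compares unfavourably with hydroxy, with a 6.2-fold higher number from compound 1 to compound 3 (0.79 log units; beyond the scatter), which places hydroxy between the other two groups and shows that acetyl does not behave like trifluoromethyl here, even though both differ from hydroxy. Nothing available here accounts for the effect of acetyl on this number.

A methyl ester, a primary amide or a nitrile on the same carbon could show whether the high number goes with the carbonyl of acetyl or with something more particular to that group. It also remains open where a smaller substituent such as chlorine or methyl would fall among these three compounds, and so whether trifluoromethyl or acetyl is the more unusual group at this position.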